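Swapping a Ring Substituent on the Shared Core

A few compounds are considered here, and "the series" means these few. Any claim that something is new, unique, unknown or untested is made for them only; others in the source may bear on it.

Compound 1 `COc1ccc(-c2c(-c3ccc(OC)cc3)n(Cc3ccccc3)c3ncn([C@@H]4CCCC[C@H]4O)c(=N)c23)cc1` carries two methoxyphenyl groups, a benzyl group and a 2-hydroxycyclohexyl group on its core. In an ADME assay on microsomes from liver (Mus musculus, strain CD1) for metabolic stability, read by LC-MS, using NADPH, with a stated time of 60 min (a lower number here means that the compound disappears faster, a higher number that the compound lasts longer), compound 1 gives 0.487 h. Two related compounds frame that number. Compound 2 `N=c1c2c(-c3ccccc3)c(-c3ccccc3)n(Cc3ccccc3)c2ncn1CCCN1CCN(c2ccccc2)CC1` gives 0.233 h in this assay, a lower number beyond the usual scatter, so it disappears faster. Compound 3 `N=c1c2c(-c3ccccc3)c(-c3ccccc3)n(CC3CC3)c2ncn1C1CCOCC1` gives 1.13 h in this assay, a higher number beyond the usual scatter, so it lasts longer. Compound 1 therefore sits in the middle of the three.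

Compound 4 `COc1ccc(-c2c(-c3ccc(OC)cc3)n(Cc3ccccc3)c3ncn(CC4CCOC4)c(=N)c23)cc1` has not yet been measured. It differs from compound 1 in one place: (oxolan-3-yl)methyl in place of 2-hydroxycyclohexyl on an aromatic nitrogen. The change removes the only hydrogen-bond donor of the leaving group and replaces a six-membered carbon ring by a five-membered ring holding one oxygen.

For the measured compounds named here, no measured pair shows exactly this kind of change, so the expectation rests on the spread of the three known numbers. The step of a 1.1-fold higher number from compound 1 to compound 4 (0.05 log units; within the scatter) is expected to stay within the usual scatter, with no clear direction. Compound 4 is thus estimated at 0.55 h in this assay, with a range from 0.25 h to 1.2 h.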

Compound 4, half-life: 0.275 h
Compound 4: middle estimate off by 2.0-fold (0.30 log units), on the high side; the measured number falls inside the stated range.
By their numbers in this assay, from the lowest: compounds 2, 4 and 1 (each within the scatter of the next, the first and the last beyond it); then compound 3.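

For the compounds shown here, this is the first pair of compounds that differ in one place only, and in this assay it gives a 1.8-fold lower number from compound 1 to compound 4 (0.25 log units; within the scatter) as its step. At this aromatic nitrogen, then, (oxolan-3-yl)methyl in place of 2-hydroxycyclohexyl removes a hydrogen-bond donor and two defined stereocentres, and the outcome cannot be told apart from the differences seen between repeated measurements. Nothing measured here offers an explanation for this result, and one pair cannot show how this position behaves in general.

From the compounds shown here alone, a plain cyclohexyl group on the same core would separate the loss of the hydroxyl from the change of ring, and that comparison remains open. Also open, going by these compounds, is whether a carboxylic acid or a longer chain at this nitrogen would move the half-life beyond the usual scatter.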